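Swapping a methoxyphenyl for a cycloheptyl ring

A few compounds are considered here, and "the series" means these few. Any claim that something is new, unique, unknown or untested is made for them only; others in the source may bear on it.

For the measured compounds named here, in a functional assay on the whole organism for antagonist activity, with Mus musculus as the target (a lower number here means that less compound is needed, a higher number that more compound is needed for the effect), compound 2 `COc1ccc(CN2CCC(C(=O)Nc3cc(Cl)c(N)cc3OC)CC2)cc1` gives 0.9 mg/kg, the only firm number in this set. Compound 1 `COc1cc(N)c(Cl)cc1NC(=O)C1CCN(Cc2cccc(C#N)c2)CC1` reaches only a limit of this assay, > 4 mg/kg, as the limit of > 4 mg/kg in this assay, at which 1 of the 2 values shown sits, records. The step of an at least 4.4-fold lower number from compound 1 to compound 2 (0.64 log units; beyond the scatter) shows that the group at this position can shift the dose markedly. Compound 3 `COc1cc(N)c(Cl)cc1NC(=O)C1CCN(CC2CCCCCC2)CC1` carries cycloheptyl in place of 4-methoxyphenyl on a saturated chain carbon bound to an amine nitrogen in a ring. Going by the values given here, no measured step tests an aromatic-to-saturated ring swap here, so the forecast is loosely held. Compound 3 is expected to give 2 mg/kg, between 0.6 mg/kg and 8 mg/kg. This expected step a 2.2-fold higher number from compound 2 to compound 3 (0.35 log units; beyond the scatter) means a modest weakening, with real uncertainty.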

Compound 3, dose for half-maximal effect: > 10 mg/kg
Compound 3: no number, only a limit; the forecaster's own chance of this, stated with the estimate: 30%; at least 5.0-fold (0.69 log units) between middle value and limit.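

Cycloheptyl does not stand in for 4-methoxyphenyl on this saturated chain carbon: in this assay the change gives an at least 11-fold higher number from compound 2 to compound 3 (1.04 log units; beyond the scatter). Compound 3 gives no number, only a limit: the limit of > 10 mg/kg in this assay, at which 1 of the 3 values shown sits. Compound 1 also stops at a limit, the step between compound 1 and compound 3 cannot be read, and of these three groups only 4-methoxyphenyl gives a firm number.

The change removes the aromatic ring and the methoxy oxygen together, and the compounds shown do not tell these two apart. Going by these compounds, a plain phenyl group in the same place would keep the aromatic ring without that oxygen, and its effect remains open.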